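This account rests on a few compounds, and the source may have more. Where it says the series, first, only, none or still open, it means among the compounds named here.

Measured compounds in a functional assay on MCF7 cells (Homo sapiens) for antiproliferative activity; on this read-out lower numbers stand for stronger inhibition and higher numbers for weaker inhibition:
Compound 1 `COc1ccccc1OCCCCCC/N=C(\NC#N)Nc1ccncc1` gives 1.1 nM.
Compound 2 `N#CN/C(=N\CCCCCCOc1ccccc1[N+](=O)[O-])Nc1ccncc1` gives 6.3 nM.
Compound 3 `COc1ccc(OCCCCCC/N=C(\NC#N)Nc2ccncc2)cc1` gives 37 nM.

All three share one core and differ only in the aromatic ring at the far end of the chain. Compound 2 differs from compound 1 by nitro in place of methoxy on an aromatic carbon, and this change made a 5.7-fold higher number from compound 1 to compound 2 (0.76 log units; beyond the scatter). Compound 3 differs from compound 1 by 4-methoxyphenyl in place of 2-methoxyphenyl on an oxygen on a saturated carbon, a change that made a 34-fold higher number from compound 1 to compound 3 (1.53 log units; beyond the scatter); from compound 2 to compound 3 the step was a 5.9-fold higher number from compound 2 to compound 3 (0.77 log units; beyond the scatter).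

Compound 4 `N#CN/C(=N\CCCCCCOc1ccc([N+](=O)[O-])cc1)Nc1ccncc1` has not yet been measured. It differs from compound 3 by nitro in place of methoxy on an aromatic carbon. Going by the values given here, this is the same kind of change as the one from compound 1 to compound 2, but not the same: there the nitro enters ortho to a large group, here para to a large group. Since the earlier step gave a 5.7-fold higher number from compound 1 to compound 2 (0.76 log units; beyond the scatter), and no measured case of this change para to a large group exists among these compounds, the step is expected to be of similar size, a 4.3-fold higher number from compound 3 to compound 4 (0.64 log units; beyond the scatter), with wide uncertainty. Compound 4 is therefore estimated at 160 nM, between 40 nM and 650 nM.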

Compound 4, half-maximal inhibitory concentration: 120 nM
Estimate against measurement, compound 4: 1.3-fold (0.12 log units) above, and the stated range covers the measured number.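

Nitro in place of methoxy gave a 3.2-fold higher number from compound 3 to compound 4 (0.51 log units; beyond the scatter) in this assay, and set beside the earlier case, the two steps do not differ beyond what repeat measurements would give: the same change on two cores in this assay, a 5.7-fold higher number (0.76 log units; beyond the scatter) from compound 1 to compound 2 and a 3.2-fold higher number (0.51 log units; beyond the scatter) from compound 3 to compound 4, 1.8-fold (0.25 log units) apart, within the scatter of two such steps. The change therefore carried from the 2-methoxyphenyl compound to the 4-methoxyphenyl compound with the same direction and a similar size, whereas the steps that swap the ring itself are larger, namely a 19-fold higher number from compound 2 to compound 4 (1.28 log units; beyond the scatter) and a 110-fold higher number from compound 1 to compound 4 (2.04 log units; beyond the scatter). Going by these compounds alone, this rests on only two pairs in a single assay, so it shows that the change behaved alike on these two cores, but not why it weakens inhibition or that it would do so on any other core.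

The compounds shown leave open whether an amine or a carboxylic acid in place of the nitro would follow the same trend. They also leave open whether the agreement between the two steps would survive a longer chain.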